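The source may hold more compounds than are shown below. What is called first, only, known or untested is meant among the compounds shown, and "the series" means these compounds.

Of the compounds shown here, two built on a shared core have been tested in a functional assay on A549 cells (Homo sapiens) for antiproliferative activity, read by MTT assay, with a stated time of 48 h; a lower number here means a stronger inhibitor, a higher number a weaker inhibitor. Compound 1 `COc1ccccc1-n1nncc1CN1C(=O)C2(C(C#N)=C(N)Oc3c2c2nc4ccccc4nc2c2ccccc32)c2ccccc21` gives only > 50000 nM, which is a limit of the assay rather than a measured number. Within the data shown here, compound 2 `N#CC1=C(N)Oc2c(N)cc3nc4ccccc4nc3c2C12C(=O)N(Cc1cnnn1-c1cccc(Br)c1)c1ccccc12` gives 18900 nM in this assay, the single actual number here. The remaining result is the limit of > 50000 nM in this assay, at which 1 of the 2 values shown sits. Compound 3 `N#CC1=C(N)Oc2c(N)cc3nc4ccccc4nc3c2C12C(=O)N(Cc1cnnn1-c1ccc(F)c(Cl)c1)c1ccccc12` differs from compound 2 in one place: 3-chloro-4-fluorophenyl in place of 3-bromophenyl on an aromatic nitrogen. Among the measured compounds shown here, no measured step of this kind exists, so the change is expected to shift potency no further than the usual scatter, in either direction. The estimated step is a 1.1-fold higher number from compound 2 to compound 3 (0.02 log units; within the scatter). Compound 3 is expected at 20000 nM, with a range from 8000 nM to 50000 nM.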

Compound 3, half-maximal inhibitory concentration: 43400 nM
Compound 3: middle estimate off by 2.2-fold (0.34 log units), on the low side, and the stated range covers the measured number.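

In this assay, the position on the aromatic nitrogen responds to the choice of aryl group: 3-chloro-4-fluorophenyl in place of 3-bromophenyl gives a 2.3-fold higher number from compound 2 to compound 3 (0.36 log units; beyond the scatter). This modest weakening rests on a single pair of compounds. Compound 3 also stands close to the end of the readable range, which is a limit and not a number: the limit of > 50000 nM in this assay, at which 1 of the 3 values shown sits.

Going by these compounds, the chlorine, the fluorine and the loss of bromine all change together in this one step, so their separate shares stay open. On these data alone, how a phenyl ring carrying an amine or a carboxylic acid would behave here also stays open.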